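Swapping Dimethoxyphenyl for Methylphenyl on the Shared Core

This account rests on a few compounds, and the source may have more. Where it says the series, first, only, none or still open, it means among the compounds named here.

Of the compounds shown here, two have numbers so far. Compound 1 `COc1ccc(-c2nc(SC)nc(NCCCCNc3ccnc4cc(Cl)ccc34)c2C#N)cc1` gives 3400 nM in an ADME assay on HeLa cells (Homo sapiens) for inhibition, read by cell counting; on this read-out higher numbers stand for weaker inhibition and lower numbers for stronger inhibition. Compound 2 `COc1ccc(-c2nc(SC)nc(NCCCCNc3ccnc4cc(Cl)ccc34)c2C#N)cc1OC` carries one additional methoxy group on the phenyl ring, and in this assay compound 2 gives 20000 nM. That single change, a 5.9-fold higher number from compound 1 to compound 2 (0.77 log units; beyond the scatter), leaves compound 2 with the highest number of the two measured compounds, the nearest being compound 1.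

Compound 3 `CSc1nc(NCCCCNc2ccnc3cc(Cl)ccc23)c(C#N)c(-c2ccc(C)cc2)n1` has not yet been measured. It differs from compound 2 in one place: 4-methylphenyl in place of 3,4-dimethoxyphenyl on an aromatic carbon. Part of this change removes the very methoxy group that was added in the step of a 5.9-fold higher number from compound 1 to compound 2 (0.77 log units; beyond the scatter), so a drop of roughly that size is expected to return. The other part, a methyl group standing where a methoxy group stood, has no measured counterpart among these compounds, and what it does here is unknown. Compound 3 is therefore expected to land near the number of compound 1, at about 3500 nM, within a range from 1200 nM to 10000 nM, which amounts to an expected step of a 5.7-fold lower number from compound 2 to compound 3 (0.76 log units; beyond the scatter).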

Compound 3, half-maximal inhibitory concentration: 5000 nM
Compound 3: middle estimate off by 1.4-fold (0.15 log units), on the low side; low and high end bracket the measured number.
By their numbers in this assay, from the lowest: compounds 1 and 3 (each within the scatter of the next); then compound 2.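

In this assay, replacing 3,4-dimethoxyphenyl with 4-methylphenyl on this aromatic carbon of the shared core brings a 4.0-fold lower number from compound 2 to compound 3 (0.60 log units; beyond the scatter) and confirms from a second direction that the number of compound 2 stands apart from the other two. Setting a methyl group where the single methoxy group of compound 1 stands gives a 1.5-fold higher number from compound 1 to compound 3 (0.17 log units; within the scatter) and so leaves no difference that can be read between these two groups on the phenyl ring, which means that of the three compounds only the one with two methoxy groups carries the weaker number. Nothing measured on these compounds offers a reason for this behaviour.

Within the data shown here, it remains open whether other groups on this phenyl ring, such as a fluorine atom, a hydroxyl group or an amine, would give numbers in the same range, and whether a single methoxy group on a different carbon of the ring would behave like the one in compound 1. On these data alone, only the phenyl group varies across these compounds, so the contributions of the methylsulfanyl group, the cyano group and the chain also remain unknown.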